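The source may hold more compounds than are shown below. What is called first, only, known or untested is meant among the compounds shown, and "the series" means these compounds.

In a functional assay on A549 cells (Homo sapiens) for inhibition, read by MTT assay, with a stated time of 48 h (a lower number here means a stronger inhibitor, a higher number a weaker inhibitor), the measured members of the series read:

- compound 1 `O=C(Nc1ccc(N2CCN(c3ccc(OC[C@@H]4CO[C@@](Cn5cncn5)(c5ccc(Cl)cc5Cl)O4)cc3)CC2)cc1)C(/C=C/Cl)C/C=C/C(F)(F)F`: 3830 nM
- compound 2 `O=C(Nc1ccc(N2CCN(c3ccc(OC[C@@H]4CO[C@@](Cn5cncn5)(c5ccc(Cl)cc5Cl)O4)cc3)CC2)cc1)c1cccc(F)c1`: 6640 nM
- compound 3 `O=C(Nc1ccc(N2CCN(c3ccc(OC[C@@H]4CO[C@@](Cn5cncn5)(c5ccc(Cl)cc5Cl)O4)cc3)CC2)cc1)c1ccc(F)c(F)c1`: 8690 nM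

Compound 3 carries the highest number of the three. Its nearest neighbour is compound 2, with a 1.3-fold higher number from compound 2 to compound 3 (0.12 log units; within the scatter), a gap within the scatter, so no order between the two can be read. Against compound 1 the gap is a 2.3-fold higher number from compound 1 to compound 3 (0.36 log units; beyond the scatter), a modest but real difference; the parallel step a 1.7-fold higher number from compound 1 to compound 2 (0.24 log units; within the scatter) stays within the scatter.

Compound 4 `O=C(Nc1ccc(N2CCN(c3ccc(OC[C@@H]4CO[C@@](Cn5cncn5)(c5ccc(Cl)cc5Cl)O4)cc3)CC2)cc1)c1cccs1` differs from compound 3 in one place: thiophen-2-yl in place of 3,4-difluorophenyl on a carbonyl carbon. Among the measured compounds shown here, no measured step bears directly on an aryl-to-thiophene exchange at the carbonyl carbon. For the measured compounds named here, the only step among aryl amides, from compound 2 to compound 3, is within the scatter, and the two aryl amides together sit only modestly apart from compound 1. The expectation for compound 4 in this assay is therefore a step of a 1.2-fold lower number from compound 3 to compound 4 (0.09 log units; within the scatter), with no direction beyond the scatter claimed. The estimated value for compound 4 is 7000 nM, expected to lie between 3500 nM and 14000 nM.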

Compound 4, half-maximal inhibitory concentration: 4330 nM
Beside the measured number, compound 4's estimate is 1.6-fold (0.21 log units) above it; the range from low to high includes it.
By their numbers in this assay, from the lowest: compounds 1, 4, 2 and 3 (each within the scatter of the next, the first and the last beyond it).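

In this assay, thiophen-2-yl on the carbonyl carbon stays within the scatter of both fluorinated phenyl amides, with a 2.0-fold lower number from compound 3 to compound 4 (0.30 log units; within the scatter) at the edge of that scatter and a 1.5-fold lower number from compound 2 to compound 4 (0.19 log units; within the scatter) inside it. The open chain of compound 1 is not separated from this ring either, at a 1.1-fold higher number from compound 1 to compound 4 (0.05 log units; within the scatter), so the gap between compound 1 and compound 3 is not a clean divide between chain and aryl groups: compound 4, with a five-membered ring holding sulfur, lies within the scatter of both. Nothing measured here accounts for these numbers.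

Still open, from the compounds shown here alone, is whether a pyridin-3-yl ring, a saturated amine such as piperidin-4-yl or a carboxylic acid on this carbonyl carbon would give a step beyond the scatter from compound 4. Also open, going by these compounds, is whether thiophen-2-yl carrying a chloro group would stay within it.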